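Phenyl Enters on the Carbon Bound to Selenium

This account rests on a few compounds, and the source may have more. Where it says the series, first, only, none or still open, it means among the compounds named here.

Of the compounds shown here, three sharing one selenium-bearing core have been tested in a functional assay on HepG2 cells (Homo sapiens) for cytotoxicity, read by MTT assay, with a stated time of 72 h; on this read-out lower numbers stand for stronger inhibition of growth and higher numbers for weaker inhibition of growth. Compound 1 `C[Se]/C(=N\C(=O)c1cc2ccccc2s1)NC(=O)c1cc2ccccc2s1` gives 41000 nM. Compound 2 `O=C(/N=C(/NC(=O)c1cccs1)[Se]Cc1ccccc1)c1cccs1` gives 58100 nM, and compound 3 `O=C(/N=C(/NC(=O)c1ccno1)[Se]Cc1ccccc1)c1ccno1` gives 58900 nM; each of these sits within the usual scatter of the number for compound 1, so the three cannot be told apart on this read-out. Compound 4 `O=C(/N=C(/NC(=O)c1cc2ccccc2s1)[Se]Cc1ccccc1)c1cc2ccccc2s1` has not yet been measured. It differs from compound 1 by phenyl in place of hydrogen on a saturated chain carbon bound to a selenium atom. Compound 2 and compound 3 already carry benzyl bound to a selenium atom and land close to compound 1, which gives no sign that this change moves the read-out. The expected change is a 1.2-fold higher number from compound 1 to compound 4 (0.07 log units; within the scatter), that is, none beyond the scatter. Compound 4 is expected to give about 48000 nM, somewhere between 20000 nM and 110000 nM.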

Compound 4, concentration for total growth inhibition: 49000 nM
For compound 4 the middle estimate is 1.0-fold (0.01 log units) below the measured one; the range from low to high includes it.
By their numbers in this assay, from the lowest: compounds 1, 4, 2 and 3 (each within the scatter of the next).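

For the compounds shown here, this is the first direct reading of the change, since only methyl to benzyl separates the two compounds: in this assay phenyl in place of hydrogen on a saturated chain carbon bound to a selenium atom gives a 1.2-fold higher number from compound 1 to compound 4 (0.08 log units; within the scatter). Compound 2 and compound 3 could only hint at this, as they also differ from compound 1 elsewhere. No available evidence bears on why the added phenyl leaves the read-out within the scatter.

The compounds shown leave open whether a different group at this place, such as a longer chain ending in an amine or a carboxylic acid, would move the number beyond the scatter.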